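Three Cytotoxicity Values and an Expected Fourth

The source may hold more compounds than are shown below. What is called first, only, known or untested is meant among the compounds shown, and "the series" means these compounds.

In an ADME assay on HepG2 cells (Homo sapiens) for cytotoxicity, read by luminescence, CellTiter-Glo and ATP content, with a stated time of 72 h (a lower number here means that less compound is needed, a higher number that more compound is needed for the effect), compound 1 `COc1cccc(Oc2ccc3c(NCCCNCc4cc(F)ccc4OC)ccnc3c2)c1` gives 7100 nM.
In this assay, compound 2 `COc1ccc(F)cc1CNCCCNc1ccnc2cc(Oc3ccc(F)cc3)ccc12` gives 6600 nM.
In this assay, compound 3 `COc1ccc(-c2ccc3c(NCCCNCc4cc(F)ccc4OC)ccnc3c2)cc1` gives 5960 nM.

Compound 3 carries the lowest of the three numbers, but its separation from the others is small: a 1.2-fold lower number from compound 1 to compound 3 (0.08 log units; within the scatter) and a 1.1-fold lower number from compound 2 to compound 3 (0.04 log units; within the scatter), so all three sit within the scatter of one another. Compound 4 `COc1ccc(F)cc1CNCCCNc1ccnc2cc(Cc3cccc(C(F)(F)F)c3)ccc12` differs from compound 3 in one place: 3-(trifluoromethyl)benzyl in place of 4-methoxyphenyl on an aromatic carbon. Each of the three measured steps also swapped the group at this same place, and each was small: a 1.1-fold lower number from compound 1 to compound 2 (0.03 log units; within the scatter), a 1.2-fold lower number from compound 1 to compound 3 (0.08 log units; within the scatter), a 1.1-fold lower number from compound 2 to compound 3 (0.04 log units; within the scatter). Among the compounds with values here, none of them introduced a 3-(trifluoromethyl)benzyl group, so no direct precedent exists for this change. Given that every exchange at this place so far stayed within the scatter, no step beyond the scatter is expected here either. Compound 4 is therefore expected to give 6000 nM, with a range from 2500 nM to 14000 nM. The expected step is a 1.0-fold higher number from compound 3 to compound 4 (0.00 log units; within the scatter).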

Compound 4, half-maximal effective concentration: 440 nM
Compound 4: middle estimate off by 14-fold (1.13 log units), on the high side, and the stated range ends above it.
By their numbers in this assay, from the lowest: compound 4; then compounds 3, 2 and 1 (each within the scatter of the next).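

Within the data shown here, replacing 4-methoxyphenyl with 3-(trifluoromethyl)benzyl gives a 14-fold lower number from compound 3 to compound 4 (1.13 log units; beyond the scatter) in this assay and shows that this place on the shared core is not as indifferent as the earlier compounds suggested. The picture holds for the other two groups, with a 15-fold lower number from compound 2 to compound 4 (1.18 log units; beyond the scatter) against 4-fluorophenoxy and a 16-fold lower number from compound 1 to compound 4 (1.21 log units; beyond the scatter) against 3-methoxyphenoxy as the group that leaves. Exchanges among the three earlier groups all stayed within the scatter, so only compound 4 reveals that a group at this place can move the number this far.

As far as these compounds go, whether the drop belongs to the benzyl link or to the trifluoromethyl stays open, and a plain benzyl group with no trifluoromethyl would separate the two. No measurement at hand speaks to the reason for the drop.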